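The source may hold more compounds than are shown below. What is called first, only, known or untested is meant among the compounds shown, and "the series" means these compounds.

Values in a physicochemical assay for solubility, read by spectrophotometry, measured as kinetic solubility, at pH 8, tested at 500 uM (a lower number here means a less soluble compound, a higher number a more soluble compound), by compound
- compound 1 `Cn1cc(NC(=O)c2ccncc2Nc2cc(-c3ccc4ccn(C)c4c3)c3nccnc3c2)cn1` at 2 ug/mL
- compound 2 `CN1CCC(NC(=O)c2ccncc2Nc2cc(-c3ccc4ccn(C)c4c3)c3nccnc3c2)CC1=O` at 48 ug/mL
- compound 3 `CC(=O)N1CCOC(CNC(=O)c2ccncc2Nc2cc(-c3ccc4ccn(C)c4c3)c3nccnc3c2)C1` at 268 ug/mL

Compound 3 at 268 ug/mL stands highest of the three. Compound 4 `CN1CC(NC(=O)c2ccncc2Nc2cc(-c3ccc4ccn(C)c4c3)c3nccnc3c2)C1` carries 1-methylazetidin-3-yl in place of (4-acetylmorpholin-2-yl)methyl on an amide-type nitrogen. All three measured steps changed this same place: two large (a 24-fold higher number from compound 1 to compound 2 (1.38 log units; beyond the scatter) and a 130-fold higher number from compound 1 to compound 3 (2.13 log units; beyond the scatter)) and one modest (a 5.6-fold higher number from compound 2 to compound 3 (0.75 log units; beyond the scatter)). The large ones both start from compound 1, whose group does not enter here, so the modest step is the closer guide. Among the compounds with values here, no measured compound carries the entering group, which keeps the range wide. A modest step to a lower number is expected in this assay (a 2.2-fold lower number from compound 3 to compound 4 (0.35 log units; beyond the scatter)). For compound 4 the estimate is 120 ug/mL (expected range 30 ug/mL to 280 ug/mL).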

Compound 4, solubility: 170 ug/mL
Compound 4: middle estimate off by 1.4-fold (0.15 log units), on the low side, within the range that was stated.
By their numbers in this assay, from the lowest: compound 1; then compound 2; then compounds 4 and 3 (each within the scatter of the next).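

On the amide-type nitrogen, 1-methylazetidin-3-yl and (4-acetylmorpholin-2-yl)methyl cannot be told apart in this assay (a 1.6-fold lower number from compound 3 to compound 4 (0.20 log units; within the scatter)), so among these compounds a number at this level does not depend on the six-membered ring or the acetyl group. The 1-methylazetidin-3-yl group also stands clear of the two other amides (a 3.5-fold higher number from compound 2 to compound 4 (0.55 log units; beyond the scatter) and an 85-fold higher number from compound 1 to compound 4 (1.93 log units; beyond the scatter)). From the compounds shown here alone, whether azetidin-3-yl without the methyl, or a chain ending in a carboxylic acid, holds this assay at this level stays open. Nothing at hand explains the differences between these groups.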